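The compounds below may be only part of what the source reports. "The series", "measured", "known", "first", "only" and "open" are said of these compounds alone.

Working notes on the series, read in an ADME assay on the whole organism (strain Sprague-Dawley) for pharmacokinetics, with Rattus norvegicus as the target, read by LC-MS, using cassette dosing, at a dose of 0.5 mg/kg by the intravenous route; on this read-out lower numbers stand for slow clearance and higher numbers for fast clearance. Compound 1 `C[C@@]1(c2cc(NC(=O)c3ncc(C#N)cc3Cl)ccc2F)C=C(CF)OC(N)=N1` gives 30.6 mL/min/kg. Compound 2 `C[C@@]1(c2cc(NC(=O)c3coc(C(F)F)n3)ccc2F)C=C(CF)OC(N)=N1` gives 28.4 mL/min/kg, so the two stand within the scatter of each other and cannot be ordered. Compound 3 `COc1cc(C#N)cnc1C(=O)Nc1ccc(F)c([C@]2(C)C=C(CF)OC(N)=N2)c1` keeps the shared core and differs from compound 2 only on a carbonyl carbon whose other neighbour is an amide-type nitrogen: 5-cyano-3-methoxypyridin-2-yl in place of 2-(difluoromethyl)-1,3-oxazol-4-yl on a carbonyl carbon. For the measured compounds named here, one measured step bears on this place, a 1.1-fold lower number from compound 1 to compound 2 (0.03 log units; within the scatter), and it exchanged 3-chloro-5-cyanopyridin-2-yl for 2-(difluoromethyl)-1,3-oxazol-4-yl. Going by the values given here, the entering 5-cyano-3-methoxypyridin-2-yl is also a cyano-substituted pyridinyl, though no measured compound carries it. On that single small step, no change beyond the scatter is expected in this assay, and the expected step is a 1.1-fold higher number from compound 2 to compound 3 (0.02 log units; within the scatter). For compound 3 the estimated clearance is 30 mL/min/kg, with an expected range of 17 mL/min/kg to 52 mL/min/kg.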

Compound 3, clearance: 36.6 mL/min/kg
The estimate for compound 3 lay 1.2-fold (0.09 log units) below the measured number; the range from low to high includes it.
By their numbers in this assay, from the lowest: compounds 2, 1 and 3 (each within the scatter of the next).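

In this assay the place on the carbonyl carbon now carries a third group, and 5-cyano-3-methoxypyridin-2-yl in place of 2-(difluoromethyl)-1,3-oxazol-4-yl gives a 1.3-fold higher number from compound 2 to compound 3 (0.11 log units; within the scatter) so a second exchange of the five-membered ring for a six-membered one also leaves clearance unresolved. The series also gains a smaller change within the pyridinyl group, where methoxy in place of chloro on an aromatic carbon gives a 1.2-fold higher number from compound 1 to compound 3 (0.08 log units; within the scatter) and so does not separate these two compounds either. Compounds 1, 2 and 3 therefore cannot be ordered at this place. Still open, as far as these compounds go, is whether a group of another kind here, such as an aliphatic amine or a carboxylic acid, would give a step beyond the scatter. No measured information on the series offers an explanation for these clearance numbers.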